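Adding One Fluoro to a Weak Growth Inhibitor

The source may report more compounds than this note shows. Statements on the series, on what has been measured and on what is new or still open speak of the compounds shown alone.

- compound 1 `c1ccc(-c2ccc(-c3ccc(-c4nc5ccccc5[nH]4)cc3)cc2)cc1` gives 41200 nM
- compound 2 `Cc1ccc2[nH]c(-c3ccc(-c4ccc(-c5ccc(N(C)C)cc5)cc4)cc3)nc2c1` gives 8120 nM
- compound 3 `COc1ccc(-c2ccc(-c3ccc(-c4nc5cc(C)ccc5[nH]4)cc3)cc2)cc1OC` gives 2560 nM

In a functional assay on PC-3 cells (Homo sapiens) for inhibition, read by sulforhodamine B assay (on this read-out higher numbers stand for weaker inhibition of growth and lower numbers for stronger inhibition of growth), compound 1 has the highest number of the three, at 41200 nM, which makes it the weakest growth inhibitor measured so far. Compound 2 and compound 3 both give clearly lower numbers, but each differs from compound 1 in more than one place, so their values cannot be credited to any single change.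

Compound 4 `Fc1ccc(-c2ccc(-c3ccc(-c4nc5ccccc5[nH]4)cc3)cc2)cc1` differs from compound 1 in one place only: fluoro in place of hydrogen on an aromatic carbon. The change sits para to a large group and turns phenyl into 4-fluorophenyl.

Within the data shown here, only one measured step changes a single group on an aromatic carbon, namely a 3.2-fold lower number from compound 2 to compound 3 (0.50 log units; beyond the scatter). That step exchanges two whole substituted phenyl groups and involves no fluoro, so it is only a loose guide. It does suggest that a single change of this kind can move the number modestly. A modest move toward a lower number is therefore expected, though a result within the scatter would be no surprise. The estimated change is a 2.3-fold lower number from compound 1 to compound 4 (0.36 log units; beyond the scatter). For compound 4 the expected value is 18000 nM, with an estimated range from 7000 nM to 42000 nM.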

Compound 4, concentration for 50% growth inhibition: 41200 nM
Compound 4: middle estimate off by 2.3-fold (0.36 log units), on the low side, within the range that was stated.
By their numbers in this assay, from the lowest: compound 3; then compound 2; then compounds 1 and 4 (each within the scatter of the next).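

In this assay, putting fluoro in place of hydrogen on this aromatic carbon, which turns phenyl into 4-fluorophenyl, gives no change at the digits printed from compound 1 to compound 4 (within the scatter). Among these compounds, this is the first measured change in a single place on the core of compound 1, and it shows that this position tolerates a fluorine atom while adding a single fluorine atom here brings no measurable gain in growth inhibition, so this small swap alone offers no route toward stronger inhibition of growth. No measurement available here explains why the number stays where it is.

As far as these compounds go, what remains open is whether a different kind of group at this same place, such as a carboxylic acid, a primary amine or a longer chain, would move the number where fluoro does not. From the compounds shown here alone, it is also open whether fluoro would leave the number just as unmoved on another carbon of this ring, or in a compound that already gives a lower number, such as compound 3.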